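This account rests on a few compounds, and the source may have more. Where it says the series, first, only, none or still open, it means among the compounds named here.

Of the compounds shown here, three of one family have been tested in a functional assay on HCT-116 cells (Homo sapiens) for cytotoxicity, read by crystal violet staining, with a stated time of 7 days; on this read-out higher numbers stand for weaker inhibition and lower numbers for stronger inhibition. Compound 1 `COc1ccccc1C(=O)/C=C/C1=Cc2cc(Br)ccc2OC1` gives 6130 nM. Compound 3 `COc1cc(OC)cc(C(=O)/C=C/C2=Cc3cc(Br)ccc3OC2)c1` gives 3400 nM in this assay, a number within the usual scatter of that of compound 1, so the two cannot be told apart. The difference between the cores of compound 1 and compound 3 is not broken down here.

Compound 2 `COc1cc(OC)cc(C(=O)/C=C/C2=Cc3cc(OC)ccc3OC2)c1` gives 35500 nM in this assay. It is related to compound 3 by a single change, (methoxy in place of bromo on an aromatic carbon), and this change made a large step, a 10-fold higher number from compound 3 to compound 2 (1.02 log units; beyond the scatter).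

Compound 4 `COc1ccc2c(c1)C=C(/C=C/C(=O)c1ccccc1OC)CO2` has not yet been measured. For the measured compounds named here, it is related to compound 1 by methoxy in place of bromo on an aromatic carbon, the same change as the one from compound 3 to compound 2, made at the same place on the shared core. Because the earlier change gave a 10-fold higher number from compound 3 to compound 2 (1.02 log units; beyond the scatter), a step of similar size is expected for compound 4, a 9.8-fold higher number from compound 1 to compound 4 (0.99 log units; beyond the scatter). On that basis compound 4 is estimated to give 60000 nM in this assay, with a likely range from 20000 nM to 150000 nM.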

Compound 4, half-maximal inhibitory concentration: 1040 nM
The estimate for compound 4 lay 58-fold (1.76 log units) above the measured number; the whole stated range lies above it.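

In this assay, methoxy in place of bromo on the core of compound 1 gave a 5.9-fold lower number from compound 1 to compound 4 (0.77 log units; beyond the scatter), which runs in the opposite direction to the step seen on the other core. The two results for this single change do not agree: the same change on two cores in this assay, a 10-fold higher number (1.02 log units; beyond the scatter) from compound 3 to compound 2 and a 5.9-fold lower number (0.77 log units; beyond the scatter) from compound 1 to compound 4, 62-fold (1.79 log units) apart, beyond the scatter of two such steps. This shows that, among these compounds, the result of the swap on one core is no reliable guide to its result on the other, not even to its direction, but it does not show which feature of the two cores lies behind the difference, and each core offers only one pair of compounds.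

The compounds shown leave open whether other groups at this place, such as an amine, a carboxylic acid or a nitrile, would behave differently on the two cores as well. They also leave open which of the two opposite results, if either, the same swap would follow on a third core.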